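A few compounds are considered here, and "the series" means these few. Any claim that something is new, unique, unknown or untested is made for them only; others in the source may bear on it.

Measured compounds:
compound 1, `Oc1ccc(-c2cc(-c3ccccc3)nc(-c3ccccc3Cl)c2)cc1`, 5460 nM
compound 2, `Oc1cccc(-c2cc(-c3cccc(Cl)c3)nc(-c3ccccn3)c2)c1`, "not determined" (no result reported)
compound 3, `Oc1cccc(-c2cc(-c3ccc(Cl)cc3)nc(-c3cccnc3)c2)c1`, 18100 nM

In a functional assay on T47D cells (Homo sapiens) for cytotoxicity, read by CCK-8 assay and cell counting, with a stated time of 2 days (a higher number here means a weaker inhibitor, a lower number a stronger inhibitor), compound 1 gives 5460 nM, the lowest of the two numbers in hand. Compound 3 gives 18100 nM in this assay, a gap beyond the scatter, so compound 1 is the stronger of the two. For compound 2 this assay shows "not determined" (no result reported), so nothing can be said of it.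

Compound 4, `Oc1ccc(-c2cc(-c3ccco3)nc(-c3ccccc3Cl)c2)cc1`, is the untested analog. It differs from compound 1 only as follows: furan-2-yl in place of phenyl on an aromatic carbon. For the measured compounds named here, the shared core and the 2-chlorophenyl and 4-hydroxyphenyl groups stay as in compound 1, and no pair of measured compounds shows this exchange, so the direction cannot be read from the data. A change of this size at this position is expected to move the number little, if at all, beyond the scatter, with a slight lean towards a weaker result.

Compound 4 is therefore expected to give 7000 nM in this assay, within 2500 nM to 20000 nM, the step being estimated as a 1.3-fold higher number from compound 1 to compound 4 (0.11 log units; within the scatter).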

Compound 4, half-maximal inhibitory concentration: 5480 nM
Estimate against measurement, compound 4: 1.3-fold (0.11 log units) above; measured number inside the range.
By their numbers in this assay, from the lowest: compounds 1 and 4 (each within the scatter of the next); then compound 3.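

In this assay, furan-2-yl in place of phenyl next to the ring nitrogen gives a 1.0-fold higher number from compound 1 to compound 4 (0.00 log units; within the scatter). This is the first exchange shown at this position, and it indicates that a five-membered aromatic ring with a hydrogen-bond acceptor can stand where a six-membered carbon ring with none stood, with the two numbers inside the scatter of each other. No measurement at hand offers an explanation for this result.

As far as these compounds go, it remains open whether this position accepts anything other than an aromatic ring, such as an amine, a carboxylic acid or a longer alkyl chain. From the compounds shown here alone, it is also open whether the same exchange would leave the number within the scatter if the 2-chlorophenyl or 4-hydroxyphenyl group were replaced.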